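The source may hold more compounds than are shown below. What is called first, only, known or untested is meant among the compounds shown, and "the series" means these compounds.

Compound 1, `CN(C)C(=O)c1cc2cnc(Nc3ccc(C(=O)NCCCN=C=S)cc3F)nc2n1C1CCCC1`, and compound 2, `CN(C)C(=O)c1cc2cnc(Nc3ccc(C(=O)NCCCCN=C=S)cc3F)nc2n1C1CCCC1`, share a core and differ only at the end of the chain that carries the isothiocyanate. In a functional assay on A549 cells (Homo sapiens) for inhibition, read by CCK-8 assay, with a stated time of 72 h, tested at 10 uM (a lower number here means a weaker effect, a higher number a stronger effect of the compound at the concentration tested), compound 1 gives 60.2%, while compound 2 gives 24.4%. The change between them, (a group of 4 heavy atoms (2 carbon, 1 nitrogen, 1 sulfur; no ring) in place of a group of 3 heavy atoms (1 carbon, 1 nitrogen, 1 sulfur; no ring), on a saturated chain carbon, three bonds along the chain from an amide-type nitrogen), carries the step of a number 35.8 percentage points lower from compound 1 to compound 2 (beyond the scatter).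

Compound 3, `CN(C)C(=O)c1cc2cnc(Nc3ccc(C(=O)NCCCN=C=S)cc3O)nc2n1C1CCCC1`, differs from compound 1 through (hydroxy in place of fluoro on an aromatic carbon), and in this assay compound 3 gives 73%, the step being a number 12.8 percentage points higher from compound 1 to compound 3 (beyond the scatter). Among the three measured compounds, compound 3 stands highest in this assay, with compound 1 nearest and compound 2 furthest.

Compound 4, `CN(C)C(=O)c1cc2cnc(Nc3ccc(C(=O)NCCCCN=C=S)cc3O)nc2n1C1CCCC1`, has not yet been measured. It stands to compound 3 as compound 2 stands to compound 1: the change is a group of 4 heavy atoms (2 carbon, 1 nitrogen, 1 sulfur; no ring) in place of a group of 3 heavy atoms (1 carbon, 1 nitrogen, 1 sulfur; no ring), on a saturated chain carbon, three bonds along the chain from an amide-type nitrogen, and it sits at the same place as the change from compound 1 to compound 2, so it is the same change, made on the core of compound 3 rather than the core of compound 1. The two cores differ by hydroxy in place of fluoro on an aromatic carbon.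

Because the same lengthening of the chain produced a number 35.8 percentage points lower from compound 1 to compound 2 (beyond the scatter), a drop of similar size is expected for compound 4, so that the estimated step is a number 35 percentage points lower from compound 3 to compound 4 (beyond the scatter) in this assay. On that basis compound 4 is expected to give about 38% in this assay, most likely between 20% and 56%. Going by the values given here, with only one prior instance of this change, the expectation rests on a single step and remains uncertain.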

Compound 4, a percentage reported as inhibition, at one concentration (the size of the read-out at that concentration, not a potency): 41.7%
Compound 4: middle estimate off by 3.7 percentage points, on the low side; the measured number falls inside the stated range.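

In this assay, going by these compounds alone, the lengthening of the chain carries over to the core of compound 3, the new step being a number 31.3 percentage points lower from compound 3 to compound 4 (beyond the scatter), and it matches the earlier step: the same change on two cores in this assay, a number 35.8 percentage points lower (beyond the scatter) from compound 1 to compound 2 and a number 31.3 percentage points lower (beyond the scatter) from compound 3 to compound 4, 4.5 percentage points apart, within the scatter of two such steps Read the other way, hydroxy in place of fluoro on an aromatic carbon also holds on the longer chain, with a step of a number 17.3 percentage points higher from compound 2 to compound 4 (beyond the scatter), which matches its earlier counterpart: the same change on two cores in this assay, a number 12.8 percentage points higher (beyond the scatter) from compound 1 to compound 3 and a number 17.3 percentage points higher (beyond the scatter) from compound 2 to compound 4, 4.5 percentage points apart, within the scatter of two such steps The four compounds thus show the two changes adding up within the scatter, but this covers only two cores, one pair of chain lengths and a single cell line at one concentration, so it shows neither a general rule for the series nor why either change moves the read-out.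

The compounds shown leave open whether a shorter chain or a still longer chain would continue the trend seen with these two lengths. They also leave open how an acrylamide or a plain amine in place of the isothiocyanate would behave, and whether methoxy or chloro on the aromatic carbon would follow hydroxy or fluoro.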